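Benzyloxy variation on the shared core in this assay

This account rests on a few compounds, and the source may have more. Where it says the series, first, only, none or still open, it means among the compounds named here.

Two compounds of the series have numbers in an assay for inhibition of Amine oxidase [flavin-containing] B (Rattus norvegicus); a higher number here means a weaker inhibitor, a lower number a stronger inhibitor. Compound 1 `N#CCCn1nc(-c2ccc(OCc3ccc([N+](=O)[O-])cc3)cc2)oc1=O` gives 5500 nM in this assay. Compound 2 `Cc1cccc(COc2ccc(C3=NN(CCC#N)C(=O)CO3)cc2)c1` gives 31 nM in this assay, the lower of the two numbers, with compound 1 standing far higher, well beyond the scatter. Compound 3 `N#CCCN1N=C(c2ccc(OCc3ccc(Cl)cc3)cc2)OCC1=O` is not yet measured. The change from compound 2 to compound 3 is 4-chlorophenyl in place of 3-methylphenyl on a saturated chain carbon bound to an oxygen on an aromatic ring. Among the measured compounds shown here, no measured pair shows this exact change, so the size of the step is not fixed by the numbers at hand; the only other benzyloxy variant is compound 1, which carries a different group and sits much higher. The step from compound 2 to compound 3 is expected to be small, a 1.6-fold higher number from compound 2 to compound 3 (0.21 log units; within the scatter), at or near the scatter, in the weaker direction if any. Compound 3 is estimated at 50 nM in this assay, within 12 nM to 250 nM.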

Compound 3, half-maximal inhibitory concentration: 100 nM
Compound 3: middle estimate off by 2.0-fold (0.30 log units), on the low side, and the stated range covers the measured number.
By their numbers in this assay, from the lowest: compound 2; then compound 3; then compound 1.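

In this assay, the aryl group of the benzyloxy unit on the shared core is a position where a change of equal heavy-atom count still registers: 4-chlorophenyl in place of 3-methylphenyl gives a 3.2-fold higher number from compound 2 to compound 3 (0.51 log units; beyond the scatter). This is the only pair shown that differs in one place, so it gives the first size for a change at this position, and that size is modest. No available data bear on the origin of this step.

The pair changes both the substituent and its ring position, so it remains open which of the two accounts for the step; a 3-chlorophenyl group at the same place would separate them. On these data alone, how an aminomethyl or carboxylic acid substituent on this ring would read also remains open.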